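This account rests on a few compounds, and the source may have more. Where it says the series, first, only, none or still open, it means among the compounds named here.

Measured compounds:
compound 1: `COc1ccc(N2C(=O)COc3ccc(-c4cnc5ccccc5c4)cc32)cc1` — > 40000 nM
compound 2: `O=C1COc2ccc(-c3cnc(Cl)c(NS(=O)(=O)c4ccc(F)cc4)c3)cc2N1c1ccccc1` — 14700 nM

Going by the values given here, in a functional assay on A549 cells (Homo sapiens) for antiproliferative activity, read by MTT assay, with a stated time of 72 h (on this read-out higher numbers stand for weaker inhibition and lower numbers for stronger inhibition), compound 2 gives 14700 nM, the only number among the two measured compounds. Compound 1 gives > 40000 nM, which is a limit of the assay and not a number. Compound 1 therefore sits at the limit of > 40000 nM in this assay, at which 1 of the 2 values shown sits. Among the compounds with values here, compound 1 and compound 2 differ in more than one place, so no step between measured compounds is available, and the two values show only that compound 2 returns a number where compound 1 does not.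

Compound 3 is `Cc1ccc(N2C(=O)COc3ccc(-c4cnc(Cl)c(NS(=O)(=O)c5ccc(F)cc5)c4)cc32)cc1`. It differs from compound 2 in one place: methyl in place of hydrogen on an aromatic carbon. Within the data shown here, with no measured step of this kind to draw on, the step of a 1.3-fold lower number from compound 2 to compound 3 (0.13 log units; within the scatter) is expected to stay within the usual scatter, with no clear direction. Compound 3 is accordingly estimated at 11000 nM, with a range from 4000 nM to 32000 nM.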

Compound 3, half-maximal inhibitory concentration: 30900 nM
The estimate for compound 3 lay 2.8-fold (0.45 log units) below the measured number; measured number inside the range.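

Going by these compounds alone, the change from phenyl to 4-methylphenyl gives the first readable step in this assay: a 2.1-fold higher number from compound 2 to compound 3 (0.32 log units; beyond the scatter). Within the data shown here, it shows that this position, on an aromatic carbon para to a large group, responds to a single added methyl, and that the response here runs towards weaker inhibition, which the earlier compounds could not show. Compound 1 still gives only a limit of the assay and not a number, so it adds no step at this position: the limit of > 40000 nM in this assay, at which 1 of the 3 values shown sits.

The compounds shown leave open whether the weaker inhibition goes with methyl alone or would also appear with another group at this position, such as an amine or a carboxylic acid. A single step also cannot say whether the same change would act alike on a different core.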